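Ethyl restored at the ring carbon, opposite configuration

This account rests on a few compounds, and the source may have more. Where it says the series, first, only, none or still open, it means among the compounds named here.

Measured so far:
compound 1 `CCC(=O)N[C@@H]1CCCc2c1cncc2N1C(=O)c2ccc(Cl)cc2[C@@H]1CC`: 345 nM
compound 2 `CCC(=O)N[C@@H]1CCCc2c1cncc2N1Cc2cc(Cl)ccc2C1=O`: 5210 nM

In an ADME assay on cells for inhibition of cytochrome P450 11B1, mitochondrial (Homo sapiens), read by HTRF (on this read-out lower numbers stand for stronger inhibition and higher numbers for weaker inhibition), compound 2 gives 5210 nM, the highest of the two numbers; the nearest, compound 1, gives 345 nM. Going by the values given here, the single measured step, a 15-fold higher number from compound 1 to compound 2 (1.18 log units; beyond the scatter), is hydrogen in place of ethyl on a saturated ring carbon, and it is large.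

Compound 3 `CCC(=O)N[C@@H]1CCCc2c1cncc2N1C(=O)c2ccc(Cl)cc2[C@H]1CC` differs from compound 2 by ethyl in place of hydrogen on a saturated ring carbon. Among the compounds with values here, the ethyl enters at the same ring carbon as in compound 1, but with the opposite configuration; no measured pair shows what that configuration does. From the compounds shown here alone, the step of a 15-fold higher number from compound 1 to compound 2 (1.18 log units; beyond the scatter) is the only one that bears on the change, so a lower number is expected for compound 3, with the size uncertain because the configuration is untested. For compound 3 the estimate in this assay is 1500 nM (300 nM to 6000 nM), a step of a 3.5-fold lower number from compound 2 to compound 3 (0.54 log units; beyond the scatter) expected from compound 2.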

Compound 3, half-maximal inhibitory concentration: 10200 nM
For compound 3 the middle estimate is 6.8-fold (0.83 log units) below the measured one, and the stated range ends below it.
By their numbers in this assay, from the lowest: compound 1; then compounds 2 and 3 (each within the scatter of the next).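

In this assay, ethyl on the saturated ring carbon gives no separation from hydrogen when drawn R: a 2.0-fold higher number from compound 2 to compound 3 (0.29 log units; within the scatter). Drawn S, the same ethyl gives the lowest number of the three, and the step between the two configurations is a 30-fold higher number from compound 1 to compound 3 (1.47 log units; beyond the scatter). The gain seen with ethyl therefore holds for the S configuration only, and this gap is assigned to the stereocentre at that carbon because of one thing: the fact that compounds 1 and 3 differ only in the configuration as drawn.

Open, from the compounds shown here alone, is whether a methyl, a propyl or a hydroxymethyl group at this carbon, drawn S, would match or pass compound 1 at 345 nM, and whether the R configuration stays as unproductive with them. Going by these compounds, the other stereocentre, drawn alike in all three compounds, also remains untested, so its contribution cannot be read from this set.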